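The compounds below may be only part of what the source reports. "The series", "measured", "known", "first", "only" and "open" are said of these compounds alone.

Measured in a functional assay on A549 cells (Homo sapiens) for cytotoxicity, read by MTT assay, with a stated time of 72 h; on this read-out lower numbers stand for stronger inhibition and higher numbers for weaker inhibition:
- Compound 1 `CNC(=O)c1cc(Oc2ccc(C(=O)/C=C/c3ccc(OC)c(OC)c3OC)cc2)ccn1`: "not determined" (no result reported)
- Compound 2 `CNC(=O)c1cc(Oc2ccc(C(=O)/C=C/c3ccc(F)cc3Cl)cc2)ccn1`: 21100 nM
- Compound 3 `CNC(=O)c1cc(Oc2ccc(/C=C/C(=O)c3ccc(Br)cc3)cc2)ccn1`: 20100 nM

Compound 1 has no reported result, so compound 2 can be compared only with compound 3, and their two values lie within the scatter of each other. Compound 4 `CNC(=O)c1cc(Oc2ccc(C(=O)/C=C/c3ccc(Cl)cc3Cl)cc2)ccn1` departs from compound 2 by a single exchange: chloro in place of fluoro on an aromatic carbon. This places chloro in place of fluoro on an aromatic carbon, turning 2-chloro-4-fluorophenyl into 2,4-dichlorophenyl. Among the compounds with values here, no measured pair shows this change, so the expectation rests on compound 2 at 21100 nM. The expected 1.2-fold lower number from compound 2 to compound 4 (0.09 log units; within the scatter) is no step beyond the scatter. For compound 4 the estimated value in this assay is 17000 nM, with an expected range of 8000 nM to 35000 nM.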

Compound 4, half-maximal inhibitory concentration: 9460 nM
Estimate against measurement, compound 4: 1.8-fold (0.25 log units) above, and the stated range covers the measured number.
By their numbers in this assay, from the lowest: compound 4; then compounds 3 and 2 (each within the scatter of the next).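

In this assay, chloro in place of fluoro on this aromatic carbon, para to a large group, gives a 2.2-fold lower number from compound 2 to compound 4 (0.35 log units; beyond the scatter), turning 2-chloro-4-fluorophenyl into 2,4-dichlorophenyl. This is the first step beyond the scatter among the compounds shown, and it shows that the number responds to the halogen at this position. Nothing available explains this step. The compounds shown leave open whether a trifluoromethyl group or an amine at this position would give a still lower number, and whether the step would hold without the chloro group meta to it.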